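Notes on the step from compound 1 to compound 3

The source may report more compounds than this note shows. Statements on the series, on what has been measured and on what is new or still open speak of the compounds shown alone.

compound 1 `CCOC(=O)CNC(=O)O[C@@H]1CO[C@]2(COC(C)(C)O2)[C@@](O)(C2OC2CC(C)C)[C@@H]1OC` gives 442000 nM here
compound 2 `CO[C@@H]1[C@H](OC(=O)NC(=O)CCl)CO[C@]2(COC(C)(C)O2)[C@@]1(O)C1OC1CC(C)C` gives 44000 nM; 44000 nM (2 entries) here

Both values come from a functional assay on A-431 cells (Homo sapiens) for antiproliferative activity (a higher number here means a weaker inhibitor, a lower number a stronger inhibitor), and compound 1 holds the higher number of the two, which makes it the weaker inhibitor of this pair. Compound 3 `CCOC(=O)NC(=O)O[C@@H]1CO[C@]2(COC(C)(C)O2)[C@@](O)(C2OC2CC(C)C)[C@@H]1OC` is still unmeasured. Among the measured compounds shown here, it carries ethoxycarbonyl in place of (ethoxycarbonyl)methyl on an amide-type nitrogen and no measured pair isolates this change. The expected step of a 4.4-fold lower number from compound 1 to compound 3 (0.65 log units; beyond the scatter) points toward a lower number in this assay. Compound 3 is expected to keep a higher number than compound 2, which gives 44000 nM; 44000 nM (2 entries), and this expectation rests on thin evidence. Compound 3 is estimated at 100000 nM with 15000 nM to 500000 nM as its expected range.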

Compound 3, half-maximal inhibitory concentration: 471000 nM
The estimate for compound 3 lay 4.7-fold (0.67 log units) below the measured number, and the stated range covers the measured number.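

In this assay the step of a 1.1-fold higher number from compound 1 to compound 3 (0.03 log units; within the scatter) comes with ethoxycarbonyl in place of (ethoxycarbonyl)methyl on the amide-type nitrogen. Among the compounds shown here, this is the first pair that isolates a change at this position, and this change leaves the number within the scatter. No measurement shown bears on the reason for this result.

Still open, going by these compounds, is whether a carboxylic acid in place of the ester, or a longer chain between the nitrogen and the ethoxycarbonyl, would shift the number in this assay at this position.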